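The compounds below may be only part of what the source reports. "The series", "measured", "known", "first", "only" and "open" are said of these compounds alone.

Measured compounds:
compound 1 `CCc1cc(-c2ccc(F)cc2)c(O)cc1OCCCOc1cccc(CCCCC(=O)N(C)C)c1CCC(=O)O`: 3.1 nM
compound 2 `CCc1cc(-c2ccc(F)cc2)c(O)cc1OCCCOc1ccccc1CCC(=O)O`: 8 nM

For the measured compounds named here, in an assay on isolated protein for binding affinity to leukotriene B4 receptor (Homo sapiens) (a lower number here means a stronger inhibitor, a higher number a weaker inhibitor), compound 2 stands highest of the two numbers, with compound 1 as its only neighbour, and the single measured step that bears here is a 2.6-fold higher number from compound 1 to compound 2 (0.41 log units; beyond the scatter). Compound 3 `CCc1cc(-c2ccc(F)cc2)c(O)cc1OCCCOc1cccc(CCCCC(=O)O)c1CCC(=O)O` differs from compound 2 by 4-carboxybutyl in place of hydrogen on an aromatic carbon, putting a chain back on the aromatic carbon that the earlier step left bare. A modest step downward in this assay is expected, a 2.3-fold lower number from compound 2 to compound 3 (0.36 log units; beyond the scatter). Compound 3 is estimated at 3.5 nM, with a range of 1.3 nM to 9 nM.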

Compound 3, inhibition constant: 2.3 nM
Compound 3: middle estimate off by 1.5-fold (0.18 log units), on the high side; the range from low to high includes it.
By their numbers in this assay, from the lowest: compounds 3 and 1 (each within the scatter of the next); then compound 2.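

In this assay a 4-carboxybutyl group on this aromatic carbon gives a 3.5-fold lower number from compound 2 to compound 3 (0.54 log units; beyond the scatter), so the gain seen with the dimethylcarbamoyl chain of compound 1 does not depend on an amide at the chain end. The carboxylic acid and the dimethylamide ends cannot be separated here (a 1.3-fold lower number from compound 1 to compound 3 (0.13 log units; within the scatter)). No evidence on why the chain matters is available.

Open, on these data alone, is whether chain length matters: a shorter or longer chain could be compared with the butyl one. Also open, as far as these compounds go, is whether an amine at the chain end, or an ether within the chain, would keep the gain.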